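The source may report more compounds than this note shows. Statements on the series, on what has been measured and on what is new or still open speak of the compounds shown alone.

Compound 1 `COc1ccc(Nc2nc(-c3cccc(F)c3)nc3ccc(F)cc23)cc1` gives 46800 nM in a functional assay on COLO 205 cells (Homo sapiens) for cytotoxicity, read by MTT assay, with a stated time of 48 h; a lower number here means a stronger inhibitor, a higher number a weaker inhibitor. Compound 3 `Fc1cccc(-c2nc(Nc3ccc(Cl)cc3)c3cc(F)ccc3n2)c1` gives 32600 nM. Compound 2 `COc1ccccc1Nc1nc(-c2cccc(F)c2)nc2ccc(F)cc12` gives > 50000 nM, which is a limit of the assay rather than a number.

Compound 1 holds the highest of the two numbers, with compound 3 nearest to it. Compound 4 `Fc1cccc(-c2nc(Nc3ccccc3Cl)c3cc(F)ccc3n2)c1` awaits measurement; it differs from compound 1 in one place: 2-chlorophenyl in place of 4-methoxyphenyl on a nitrogen on an aromatic ring. Among the compounds with values here, two measured steps touch this change. Exchanging chloro for methoxy gave a 1.4-fold lower number from compound 1 to compound 3 (0.16 log units; within the scatter). Moving the methoxy group gave an at least 1.0-fold higher number from compound 1 to compound 2 (0.02 log units; that floor lies within the scatter), with compound 2 reaching (the limit of > 50000 nM in this assay, at which 1 of the 3 values shown sits). Neither step rises beyond the scatter, so for compound 4 no shift beyond the scatter is expected in this assay, and the estimated step is a 1.1-fold lower number from compound 1 to compound 4 (0.05 log units; within the scatter). Compound 4 is expected to give 42000 nM, between 16000 nM and 110000 nM, with a real chance that only a limit is reported.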

Compound 4, half-maximal inhibitory concentration: > 50000 nM
Compound 4: only a limit was reported (the forecaster's own chance of this, stated with the estimate: 40%); at least 1.1-fold (0.07 log units) between middle value and limit.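

In this assay, compound 4 ends at a limit, not a number, and its steps are only floors: an at least 1.0-fold higher number from compound 1 to compound 4 (0.02 log units; that floor lies within the scatter), and an at least 1.5-fold higher number from compound 3 to compound 4 (0.18 log units; that floor lies within the scatter). Neither step shows a real change, and the step between the two limit compounds cannot be read. The new result does add a shared outcome for the 2-chlorophenyl of compound 4 and the 2-methoxyphenyl of compound 2, while the two 4-substituted compounds give numbers: the limit of > 50000 nM in this assay, at which 2 of the 4 values shown sit.

As far as these compounds go, how far compound 2 and compound 4 lie past that limit stays open. So does whether an amine or a carboxylic acid in place of the chloro would move the number beyond the scatter.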